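A Smaller Saturated Ring on the Side Chain

A few compounds are considered here, and "the series" means these few. Any claim that something is new, unique, unknown or untested is made for them only; others in the source may bear on it.

Of the compounds shown here, three sharing one core have been measured in an assay for inhibition of Indoleamine 2,3-dioxygenase 1 (Homo sapiens), with stated times of 10 min and 60 min, tested at 100 uM; a higher number here means a stronger effect of the compound at the concentration tested, a lower number a weaker effect. Compound 2 `FC(F)(F)c1cc(NC[C@H]2CCCN2)c2cn[nH]c2c1` gives 83%. Compound 3 `O=[N+]([O-])c1ccccc1CNc1cc(Br)cc2[nH]ncc12` gives 83%, level with compound 2 at the digits shown, and together these two carry the highest numbers of the three. Compound 1 `Oc1ccc(CNc2cc(C(F)(F)F)cc3[nH]ncc23)cc1` gives 81%; the step of a number 2 percentage points higher from compound 1 to compound 2 (within the scatter) lies within the scatter, so the exchange of a 4-hydroxyphenyl for a pyrrolidin-2-yl at that position left the read-out essentially unchanged.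

Compound 4 `FC(F)(F)c1cc(NCC2CNC2)c2cn[nH]c2c1` is not yet measured. It differs from compound 2 by azetidin-3-yl in place of pyrrolidin-2-yl on a saturated chain carbon bound to a nitrogen on an aromatic ring.

Among the compounds with values here, only one measured step touches the same position, the step from compound 1 to compound 2, and it was within the scatter. Within the data shown here, all three numbers so far sit close together, which gives no sign that this position is sensitive to what is attached there. The expected step of a number 5 percentage points lower from compound 2 to compound 4 (within the scatter) is therefore small, with no direction beyond the scatter. For compound 4 the estimate in this assay is 78%, with a range from 62% to 90%.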

Compound 4, a percentage reported as inhibition, at one concentration (the size of the read-out at that concentration, not a potency): 22%
Compound 4: middle estimate off by 56 percentage points, on the high side; measured number outside the range, below it.
By their numbers in this assay, from the lowest: compound 4; then compounds 1, 2 and 3 (each within the scatter of the next).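

In this assay, this position on a saturated chain carbon bound to a nitrogen on an aromatic ring proves sensitive after all: swapping the five-membered non-aromatic ring of pyrrolidin-2-yl for the four-membered one of azetidin-3-yl gives a number 61 percentage points lower from compound 2 to compound 4 (beyond the scatter) even though both groups carry the same counts of hydrogen-bond donors and acceptors. The position therefore does not accept every group equally, since the change to azetidin-3-yl also gives a number 59 percentage points lower from compound 1 to compound 4 (beyond the scatter) while the very different 4-hydroxyphenyl and pyrrolidin-2-yl stay within the scatter of each other, as a number 2 percentage points higher from compound 1 to compound 2 (within the scatter) shows. Nothing measured here bears on why the read-out falls so sharply.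

The step from compound 2 to compound 4 alters ring size, the ring atom that carries the chain and the defined stereocentre all at once, so these compounds cannot show which of the three matters. A pyrrolidin-3-yl or an azetidin-2-yl group would pull ring size apart from the point of attachment, and a piperidin-4-yl group would show whether a larger ring keeps the read-out at the level of compound 2.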